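This account rests on a few compounds, and the source may have more. Where it says the series, first, only, none or still open, it means among the compounds named here.

Of the compounds shown here, three built on a shared core have been tested in a functional assay on HepG2 cells (Homo sapiens) for cytotoxicity, read by MTT assay, with a stated time of 72 h; a lower number here means a stronger inhibitor, a higher number a weaker inhibitor. Compound 1 `O=C(Nc1ccc(Oc2ccnc3[nH]ccc23)cc1)c1nn(-c2ccccc2)ccc1=O` gives 17800 nM. Compound 2 `O=C(Nc1ccc(Oc2ccnc3[nH]ccc23)cc1)c1nn(-c2ccc(Br)cc2F)ccc1=O` gives 46400 nM, and compound 3 `O=C(Nc1ccc(Oc2ccnc3[nH]ccc23)c(F)c1)c1nn(-c2ccccc2)ccc1=O` gives 24900 nM. Compound 3 differs from compound 1 by fluoro in place of hydrogen on an aromatic carbon, a change that made a 1.4-fold higher number from compound 1 to compound 3 (0.15 log units; within the scatter). Compound 2 differs from compound 1 by 4-bromo-2-fluorophenyl in place of phenyl on an aromatic nitrogen, which made a 2.6-fold higher number from compound 1 to compound 2 (0.42 log units; beyond the scatter). Compound 4 `O=C(Nc1ccc(Oc2ccnc3[nH]ccc23)c(F)c1)c1nn(-c2ccc(Br)cc2F)ccc1=O` has not yet been measured. It differs from compound 3 by 4-bromo-2-fluorophenyl in place of phenyl on an aromatic nitrogen, the same change that separates compound 2 from compound 1, at the same place. Compound 4 is expected to show a step of a 2.6-fold higher number from compound 3 to compound 4 (0.42 log units; beyond the scatter) because the same change earlier gave a 2.6-fold higher number from compound 1 to compound 2 (0.42 log units; beyond the scatter). The estimate for compound 4 is therefore 65000 nM, with a likely range from 30000 nM to 140000 nM.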

Compound 4, half-maximal inhibitory concentration: 56500 nM
Beside the measured number, compound 4's estimate is 1.2-fold (0.06 log units) above it; the measured number falls inside the stated range.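

In this assay, putting 4-bromo-2-fluorophenyl in place of phenyl on the aromatic nitrogen gave a 2.3-fold higher number from compound 3 to compound 4 (0.36 log units; beyond the scatter), much like the earlier step on the other core: the same change on two cores in this assay, a 2.6-fold higher number (0.42 log units; beyond the scatter) from compound 1 to compound 2 and a 2.3-fold higher number (0.36 log units; beyond the scatter) from compound 3 to compound 4, 1.1-fold (0.06 log units) apart, within the scatter of two such steps. Fluoro in place of hydrogen on an aromatic carbon stayed small on both cores, at a 1.2-fold higher number from compound 2 to compound 4 (0.09 log units; within the scatter) here: the same change on two cores in this assay, a 1.4-fold higher number (0.15 log units; within the scatter) from compound 1 to compound 3 and a 1.2-fold higher number (0.09 log units; within the scatter) from compound 2 to compound 4, 1.1-fold (0.06 log units) apart, within the scatter of two such steps. So across these four compounds the two changes carry over from one core to the other, but this does not show that they would do so on other cores or in other assays.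

The compounds shown leave open whether the bromine or the fluorine on the phenyl accounts for the step, since the two enter together. They also leave open whether a phenyl carrying an amine or a carboxylic acid would follow the same pattern.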